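Mirror-image methoxy analogue at the alpha4/beta2 receptor

The source may report more compounds than this note shows. Statements on the series, on what has been measured and on what is new or still open speak of the compounds shown alone.

Measured so far: compound 1 `c1cncc(N2CC[C@@H]3CN[C@@H]3C2)c1`, 330 nM; compound 2 `Clc1ccc(N2CC[C@@H]3CN[C@@H]3C2)cn1`, 24 nM; compound 3 `COc1ccc(N2CC[C@H]3CN[C@H]3C2)cn1`, 2200 nM.

In a functional assay on HEK293 cells for agonist activity at Neuronal acetylcholine receptor; alpha4/beta2 (Homo sapiens), read by FLIPR (a lower number here means that less compound is needed, a higher number that more compound is needed for the effect), compound 3 gives the highest number of the three: against compound 1 it needs about 330 nM less, and compound 2 with its chloro group sits furthest away. Among the compounds with values here, the step of a 14-fold lower number from compound 1 to compound 2 (1.14 log units; beyond the scatter) is the only measured single change, and it concerns a ring substituent, not configuration.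

Compound 4 `COc1ccc(N2CC[C@@H]3CN[C@@H]3C2)cn1` is the mirror image of compound 3: the two compounds have the same atoms and bonds and differ only in configuration as drawn: 2 of 2 stereo elements differ (all stereocentres are inverted: mirror images); a stereocentre at a saturated ring carbon is drawn S in compound 3 and R in compound 4; a stereocentre at a saturated ring carbon is drawn R in compound 3 and S in compound 4. Compound 4 shares the drawn configuration of compounds 1 and 2. Within the data shown here, no measured pair shows what inverting both centres does, so the expected step of a 7.3-fold lower number from compound 3 to compound 4 (0.87 log units; beyond the scatter) rests on the weak standing of compound 3 alone and is uncertain; a lower number is expected for compound 4, estimated at 300 nM, within 50 nM to 2000 nM.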

Compound 4, half-maximal effective concentration: 4980 nM
Compound 4: the middle estimate sits 17-fold (1.22 log units) below what was measured; measured number outside the range, above it.
By their numbers in this assay, from the lowest: compound 2; then compound 1; then compound 3; then compound 4.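

Inverting both stereocentres gives a 2.3-fold higher number from compound 3 to compound 4 (0.35 log units; beyond the scatter), so configuration does shift the number in this assay, but only modestly, and that shift can be put down to configuration alone: the fact that compounds 3 and 4 differ only in the configuration as drawn

The group on the aromatic carbon matters far more within the shared configuration: methoxy in place of hydrogen gives a 15-fold higher number from compound 1 to compound 4 (1.18 log units; beyond the scatter), and methoxy in place of chloro gives a 210-fold higher number from compound 2 to compound 4 (2.32 log units; beyond the scatter).

Going by these compounds, only the methoxy compounds appear as a mirror-image pair, so what inversion does to the chloro compound stays open. On these data alone, how an amine on that aromatic carbon would behave also stays open.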